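The compounds below may be only part of what the source reports. "The series", "measured", "known", "first", "only" and "open" are said of these compounds alone.

Measured in a functional assay on SUP-B15 cells (Homo sapiens) for antiproliferative activity, with a stated time of 72 h; on this read-out higher numbers stand for an effect only at larger amounts of compound and lower numbers for an effect already at smaller amounts:
compound 1 `COc1ccc(-c2cc(=O)c3c(OC)cc(OC)cc3n2C)cc1`: 28000 nM
compound 2 `COc1ccc(-c2cc(=O)c3c(OC)cc(OC)cc3n2S(=O)(=O)c2ccc(C)c([N+](=O)[O-])c2)cc1`: > 51700 nM

Of the two, only compound 1 has a definite number; in this assay compound 1 gives 28000 nM. Compound 2 stands at the limit of > 51700 nM in this assay, at which 1 of the 2 values shown sits, and this is a limit of the assay rather than a measured number. So compound 2 is the one whose position on the scale remains open, and no step between it and compound 1 can be sized.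

Compound 3 `COc1ccc(-c2cc(=O)c3c(OC)cc(OC)cc3n2S(=O)(=O)c2ccc(F)cc2)cc1` keeps the sulfonyl attachment of compound 2 and changes only the group on it: 4-fluorophenyl in place of 4-methyl-3-nitrophenyl on a sulfonyl sulfur. For the measured compounds named here, because compound 2 gives > 51700 nM, there is no measured step of this kind to lean on. The change is expected to make little difference, with an estimated step of an at least 1.0-fold lower number from compound 2 to compound 3 (0.01 log units; that floor lies within the scatter) that stays within the usual scatter. For compound 3 the estimate in this assay is 50000 nM, with a range from 15000 nM to 160000 nM.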

Compound 3, half-maximal effective concentration: > 65500 nM
Compound 3 gave a limit, no number (the forecaster's own chance of this, stated with the estimate: 60%); middle value at least 1.3-fold (0.11 log units) away from the limit.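

In this assay compound 3 also ends at a limit of the assay, not a number: the limit of > 65500 nM in this assay, at which 1 of the 3 values shown sits. On these data alone, compound 2 is at a limit as well, so the step between these two cannot be read, and it stays unknown whether 4-fluorophenyl and 4-methyl-3-nitrophenyl on a sulfonyl sulfur differ at all. For the compounds shown here, the one readable step is an at least 2.3-fold higher number from compound 1 to compound 3 (0.36 log units; beyond the scatter), which shows that a second aryl sulfonyl group on the aromatic nitrogen also gives a higher number than methyl, meaning more compound is needed for an effect.

As far as these compounds go, how far either sulfonyl compound truly lies from compound 1 remains open. Also open, from the compounds shown here alone, is what a different group on the aromatic nitrogen, such as an ethyl or a longer chain ending in an amine, would do to the number.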